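The compounds below may be only part of what the source reports. "The series", "measured", "known", "first", "only" and "open" are said of these compounds alone.

Of the compounds shown here, two with a shared core have so far been measured in an assay on Sf21 cells for inhibition of high affinity nerve growth factor receptor (Homo sapiens), read by HTRF, with a stated time of 30 min, in the presence of a further agent that is not named here; a higher number here means a weaker inhibitor, a lower number a stronger inhibitor. Compound 1 `CC1(C)c2[nH]nc(NC(=O)c3ccccc3)c2CN1Cc1cccc(C#N)c1` gives 980 nM in this assay. Compound 2 `CC1(C)c2[nH]nc(NC(=O)c3ccccc3)c2CN1Cc1cccc(F)c1F` gives 200 nM in this assay. Going by the values given here, the single change between them, 2,3-difluorophenyl in place of 3-cyanophenyl on a saturated chain carbon bound to an amine nitrogen in a ring, brought a 4.9-fold lower number from compound 1 to compound 2 (0.69 log units; beyond the scatter). Compound 2 therefore holds the lowest of the two numbers, with compound 1 the nearest and higher.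

Compound 3 `CC1(C)c2[nH]nc(NC(=O)c3ccc(F)cc3)c2CN1Cc1cccc(F)c1F` has not yet been measured. It differs from compound 2 by fluoro in place of hydrogen on an aromatic carbon, so the benzoyl group becomes a (4-fluorophenyl)carbonyl group while the rest stays as in compound 2. Among the compounds with values here, no measured step touches this part of the molecule: the one step known alters the other aromatic ring, the one on the saturated chain carbon. With nothing to lean on beyond the smallness of the exchange, the expected step is a 1.2-fold lower number from compound 2 to compound 3 (0.07 log units; within the scatter), not clearly beyond the scatter in either direction. Compound 3 is thus expected to give about 170 nM in this assay, between 60 nM and 500 nM.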

Compound 3, half-maximal inhibitory concentration: 210 nM
For compound 3 the middle estimate is 1.2-fold (0.09 log units) below the measured one, and the stated range covers the measured number.
By their numbers in this assay, from the lowest: compounds 2 and 3 (each within the scatter of the next); then compound 1.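

Going by these compounds alone, the step on the benzoyl side is the first look at this part of the molecule, since the earlier step, a 4.9-fold lower number from compound 1 to compound 2 (0.69 log units; beyond the scatter) in this assay, concerned the other aromatic ring. Here, phenyl to 4-fluorophenyl gives a 1.1-fold higher number from compound 2 to compound 3 (0.02 log units; within the scatter) in this assay and so leaves compound 2 and compound 3 indistinguishable, which shows that this carbon of the ring, para to a large group, can carry a fluoro group without any measurable loss or gain. Nothing available explains why this small exchange makes no visible difference.

One fluorine is a very small probe, so the compounds shown cannot tell whether this place also accepts something larger, such as a methoxy group, a dimethylamino group or a morpholine ring, or whether any such group would move the number beyond the usual scatter in either direction. As far as these compounds go, it also stays open whether the 4-fluorophenyl exchange would behave the same way with the 3-cyanophenyl group of compound 1 in place of the 2,3-difluorophenyl group, as the exchange has been seen only alongside the latter.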